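The source may report more compounds than this note shows. Statements on the series, on what has been measured and on what is new or still open speak of the compounds shown alone.

Compound 1 `c1ccc(-c2nc3ccccn3c2NC2CCCCC2)cc1` gives > 100000 nM in an assay on membranes from brain for displacement of a labelled ligand from adenosine receptor A1 (Rattus norvegicus) (on this read-out higher numbers stand for weaker inhibition and lower numbers for stronger inhibition), which is a limit of the assay and not a number. Compound 2 `Fc1ccc(-c2nc3ccccn3c2NC2CCCCC2)cc1` likewise gives > 100000 nM in this assay, again a limit rather than a number. Compound 3 `COc1ccc(-c2nc3ccccn3c2NC2CCCCC2)cc1` gives 7610 nM in this assay.

Within the data shown here, compound 3 thus stands as the only compound of the three with a number in this assay; the other two values are limits, both sitting at the limit of > 100000 nM in this assay, at which 2 of the 3 values shown sit. Compound 4 `Cc1ccc(-c2nc3ccccn3c2NC2CCCCC2)cc1` differs from compound 3 in one place: methyl in place of methoxy on an aromatic carbon. Among the measured compounds shown here, two measured steps bear on this change. The step of an at least 13-fold lower number from compound 1 to compound 3 (1.11 log units; beyond the scatter) and the step of an at least 13-fold lower number from compound 2 to compound 3 (1.11 log units; beyond the scatter) both show that putting methoxy onto that aromatic carbon lowered the number strongly, whereas the step that the two limits leave unreadable from compound 1 to compound 2 cannot be read. Taking the methoxy away again and leaving methyl in its place is therefore expected to move the number back upward, toward the weaker side, by a step estimated as a 5.3-fold higher number from compound 3 to compound 4 (0.72 log units; beyond the scatter); a limit rather than a number is a real possibility. Compound 4 is estimated at 40000 nM, with a range from 10000 nM to 160000 nM.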

Compound 4, inhibition constant: 2060 nM
Compound 4: middle estimate off by 19-fold (1.29 log units), on the high side; the measured number lies below the stated range.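

The change to methyl gave a 3.7-fold lower number from compound 3 to compound 4 (0.57 log units; beyond the scatter) in this assay, so at this place on the aromatic ring, a low number does not require the oxygen of the methoxy group or a hydrogen-bond acceptor. Methyl in place of hydrogen gave an at least 48-fold lower number from compound 1 to compound 4 (1.68 log units; beyond the scatter), and methyl in place of fluoro gave an at least 48-fold lower number from compound 2 to compound 4 (1.68 log units; beyond the scatter), so among the groups shown, the 4-methylphenyl compound has the lowest number. Both steps start from a limit of the assay and not from a number: the limit of > 100000 nM in this assay, at which 2 of the 4 values shown sit.

The compounds shown leave open how an ethyl group, a chlorine atom or an amine on this aromatic carbon would read. They also leave open the true size of the two steps that start from a limit.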